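Removing the Terminal Phosphate from a Benzylthio Uridine Diphosphate

This account rests on a few compounds, and the source may have more. Where it says the series, first, only, none or still open, it means among the compounds named here.

Compound 1 `CSc1nc(=O)ccn1[C@@H]1O[C@H](COP(=O)(O)OP(=O)(O)O)[C@@H](O)[C@H]1O` was examined in an in vitro functional assay on 1321-N1 cells for agonist activity at P2Y purinoceptor 4 (Homo sapiens), read by scintillation proximity assay and inositol phosphate accumulation (on this read-out higher numbers stand for an effect only at larger amounts of compound and lower numbers for an effect already at smaller amounts), where compound 1 gives 1520 nM. Compound 2 `CSc1nc(=O)ccn1[C@@H]1O[C@H](COP(=O)(O)O)[C@@H](O)[C@H]1O` differs from compound 1 by a hydrogen atom in place of a group of 4 heavy atoms (3 oxygen, 1 phosphorus; no ring), on an oxygen. In this assay compound 2 reaches only a limit of the assay, > 100000 nM. The change thus produced an at least 65-fold higher number from compound 1 to compound 2 (1.81 log units; beyond the scatter), a step that rests on (the limit of > 100000 nM in this assay, at which 1 of the 3 values shown sits).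

Compound 3 `O=c1ccn([C@@H]2O[C@H](COP(=O)(O)OP(=O)(O)O)[C@@H](O)[C@H]2O)c(SCc2ccccc2)n1` carries a different core, set apart from compound 1 by phenyl in place of hydrogen on a saturated chain carbon bound to a sulfur. In this assay compound 3 gives 5980 nM, so that the step reads a 3.9-fold higher number from compound 1 to compound 3 (0.59 log units; beyond the scatter), leaving compound 3 with the higher of the two numbers.

Compound 4 `O=c1ccn([C@@H]2O[C@H](COP(=O)(O)O)[C@@H](O)[C@H]2O)c(SCc2ccccc2)n1` has not yet been measured in this assay. It differs from compound 3 by a hydrogen atom in place of a group of 4 heavy atoms (3 oxygen, 1 phosphorus; no ring), on an oxygen, the same change as that from compound 1 to compound 2, at the same kind of place. Since the earlier change gave an at least 65-fold higher number from compound 1 to compound 2 (1.81 log units; beyond the scatter), compound 4 is expected to show a 50-fold higher number from compound 3 to compound 4 (1.70 log units; beyond the scatter), a step expected to carry it beyond the reporting limit. Compound 4 is therefore estimated at 300000 nM, with a range from 60000 nM to 2000000 nM.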

Compound 4, half-maximal effective concentration: > 100000 nM
Compound 4: no number, only a limit (the forecaster's own chance of this, stated with the estimate: 85%); the middle value lies beyond the limit too.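

In this assay compound 4 reaches only a limit of the assay, > 100000 nM. The exchange of the group of 4 heavy atoms on an oxygen for a hydrogen atom thus gives an at least 16-fold higher number from compound 3 to compound 4 (1.22 log units; beyond the scatter), so on both cores shown the number rises, and in each case the step is large and ends at a limit. This shows that the direction of the change carries over from the core of compound 1 to the core of compound 3, but not that its size does, and the step between compound 2 and compound 4 cannot be read, as both are limits: the same change on two cores in this assay, an at least 65-fold higher number (1.81 log units; beyond the scatter) from compound 1 to compound 2 and an at least 16-fold higher number (1.22 log units; beyond the scatter) from compound 3 to compound 4; the limit leaves it open whether they differ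

The compounds shown leave open how a triphosphate in place of the diphosphate, or a longer chain on the sulfur, would read in this assay. They also leave open how far apart compound 2 and compound 4 truly lie, and whether either has any measurable effect in this series.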